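The source may report more compounds than this note shows. Statements on the series, on what has been measured and on what is new or still open speak of the compounds shown alone.

Measured so far in an in vitro functional assay on CHO/Galpha16 cells for antagonist activity at C-C chemokine receptor type 8 (Homo sapiens), read by FLIPR; on this read-out lower numbers stand for stronger inhibition and higher numbers for weaker inhibition:

- compound 1, `CCCC(=O)N1CCC(NS(=O)(=O)c2ccc(NC(=O)C3CCCCC3)c3ccccc23)CC1`: 6.1 nM
- compound 2, `CCCC(=O)N1CCC(NS(=O)(=O)c2ccc(NC(=O)c3ccc(C)cc3)c3ccccc23)CC1`: 9.5 nM
- compound 3, `CCCC(=O)N1CCC(NS(=O)(=O)c2ccc(NC(=O)c3ccc(F)cc3)c3ccccc23)CC1`: 59.5 nM

Compound 3 stands highest of these three numbers, meaning it is the weakest inhibitor of the set: the step is a 6.3-fold higher number from compound 2 to compound 3 (0.80 log units; beyond the scatter) and a 9.8-fold higher number from compound 1 to compound 3 (0.99 log units; beyond the scatter), both beyond the scatter. Compound 4, `CCCC(=O)N1CCC(NS(=O)(=O)c2ccc(NC(=O)c3ccc(C(C)(C)C)cc3)c3ccccc23)CC1`, differs from compound 3 in one place: tert-butyl in place of fluoro on an aromatic carbon.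

Within the data shown here, two measured steps bear on this. The step from a methyl to a fluoro at this same place, a 6.3-fold higher number from compound 2 to compound 3 (0.80 log units; beyond the scatter), shows that swapping a small carbon group for fluorine here cost potency. The step of a 1.6-fold higher number from compound 1 to compound 2 (0.19 log units; within the scatter) shows that a methylphenyl and a cyclohexyl give numbers within the scatter of each other, so an alkyl group at this place sits comfortably. Replacing the fluoro by a tert-butyl is therefore expected to undo the loss seen in compound 3, giving a step of about a 6.0-fold lower number from compound 3 to compound 4 (0.77 log units; beyond the scatter) downward in this assay, because a 6.3-fold higher number from compound 2 to compound 3 (0.80 log units; beyond the scatter) ran the other way. Compound 4 is thus estimated at 10 nM, with a range of 3 nM to 40 nM.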

Compound 4, half-maximal inhibitory concentration: 6.9 nM
Beside the measured number, compound 4's estimate is 1.4-fold (0.16 log units) above it, within the range that was stated.
By their numbers in this assay, from the lowest: compounds 1, 4 and 2 (each within the scatter of the next); then compound 3.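

At this place on the aromatic ring, tert-butyl serves as well as methyl: a 1.4-fold lower number from compound 2 to compound 4 (0.14 log units; within the scatter) shows that the extra carbons bring no change that can be told from the scatter. Fluoro is now set apart from two carbon groups rather than one, as an 8.6-fold lower number from compound 3 to compound 4 (0.94 log units; beyond the scatter) matches the earlier loss in size, while a 1.1-fold higher number from compound 1 to compound 4 (0.05 log units; within the scatter) shows that the 4-(tert-butyl)phenyl group and the cyclohexyl group on the carbonyl also cannot be told apart. Nothing available explains why fluoro alone gives the higher number.

From the compounds shown here alone, it remains open whether that loss belongs to fluoro alone or would also appear with chloro, methoxy, an amine or a carboxylic acid on this carbon. Going by these compounds, it is also open whether a longer chain, such as hexyl, would match tert-butyl and methyl here.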